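Swapping the pyrazole substituents on a glucagon receptor ligand

The source may hold more compounds than are shown below. What is called first, only, known or untested is meant among the compounds shown, and "the series" means these compounds.

Measured so far:
Compound 1 `CCCC(Oc1ccc(-n2cc(C(F)(F)F)cn2)c(C)c1)c1ccc(C(=O)NCCC(=O)O)cc1`: 200 nM
Compound 2 `CCCC(Oc1ccc(-n2cc(C#N)cn2)cc1)c1ccc(C(=O)NCCC(=O)O)cc1`: 4100 nM

Both compounds were tested in an assay on cells for displacement of a labelled ligand from Glucagon receptor (Homo sapiens), in the presence of a further agent that is not named here; a lower number here means a stronger inhibitor, a higher number a weaker inhibitor. Compound 1 gives 200 nM, while compound 2 gives 4100 nM, the higher of the two numbers, and the gap between them lies well beyond the usual scatter of this assay. Compound 2 is therefore the weaker inhibitor of the pair.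

Compound 3 `CCCC(Oc1ccc(-n2cc(C(F)(F)F)c(C)n2)cc1)c1ccc(C(=O)NCCC(=O)O)cc1` has not yet been measured. It differs from compound 2 in one place: 3-methyl-4-(trifluoromethyl)-1H-pyrazol-1-yl in place of 4-cyano-1H-pyrazol-1-yl on an aromatic carbon. The trifluoromethyl group that enters is the same one carried by compound 1, though compound 3 adds a methyl on the pyrazole rather than on the six-membered ring.

Since compound 1, which also carries a trifluoromethyl group on its pyrazole, gives 200 nM, the change from compound 2 to compound 3 is expected to lower the number considerably, by roughly a 14-fold lower number from compound 2 to compound 3 (1.14 log units; beyond the scatter). For compound 3 the estimate in this assay is 300 nM, with a plausible range from 100 nM to 1200 nM.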

Compound 3, inhibition constant: 1100 nM
Beside the measured number, compound 3's estimate is 3.7-fold (0.56 log units) below it, and the stated range covers the measured number.
By their numbers in this assay, from the lowest: compound 1; then compound 3; then compound 2.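

In this assay, exchanging one substituted pyrazole for another on the same aromatic carbon, para to a large group, gives a 3.7-fold lower number from compound 2 to compound 3 (0.57 log units; beyond the scatter), so the number does respond to what this ring carries. The exchange makes two alterations at once: the nitrile gives way to a trifluoromethyl group and a methyl group is added to the pyrazole. The step therefore belongs to the pair of alterations and cannot be divided between them. No measurement shown here explains why the number falls.

From the compounds shown here alone, it stays open whether the trifluoromethyl group or the added methyl carries the step, and a pyrazole with a single methyl, or with a chlorine atom or an amine in place of the nitrile, would help to separate the two. Compound 1 differs from compound 3 in more than one place, so the pair cannot show whether the methyl group serves better on the pyrazole or on the six-membered ring.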